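Removing One Methoxy from a Vinyl Sulfone Core

This account rests on a few compounds, and the source may have more. Where it says the series, first, only, none or still open, it means among the compounds named here.

The measured compounds in this set:
compound 1 `COc1cc(OC)c(/C=C/S(=O)(=O)Cc2ccc(OC)c(N)c2)c(OC)c1` with 30 nM
compound 2 `COc1cc(OC)c(/C=C/[S+]([O-])Cc2ccc(OC)c(N)c2)c(OC)c1` with < 10 nM
compound 3 `COc1ccc(CS(=O)(=O)CC(=O)Nc2ccccc2)cc1[N+](=O)[O-]` with > 30000 nM

For the measured compounds named here, in a functional assay on MDA-MB-468 cells (Homo sapiens) for cytotoxicity, read by MTT assay, with a stated time of 72 h (a lower number here means a stronger inhibitor of growth, a higher number a weaker inhibitor of growth), compound 1 gives 30 nM, and this is the only outright number among the three measured compounds. Compound 2 reaches a limit of the assay, < 10 nM, so only a bound is known for it (the limit of < 10 nM in this assay, at which 1 of the 3 values shown sits). Compound 3 likewise sits at a limit, > 30000 nM, and again no number is reported (the limit of > 30000 nM in this assay, at which 1 of the 3 values shown sits). Going by the values given here, since no two of the measured compounds differ in one place only, no single measured step is available to calibrate a change of the kind now considered.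

Compound 4 `COc1ccc(CS(=O)(=O)/C=C/c2c(OC)cccc2OC)cc1N` differs from compound 1 by hydrogen in place of methoxy on an aromatic carbon. With the core of compound 1 otherwise kept intact, the author expects this change to register as a step beyond the scatter, in the direction of weaker growth inhibition, giving a 10-fold higher number from compound 1 to compound 4 (1.00 log units; beyond the scatter). The estimated value for compound 4 in this assay is therefore 300 nM, with a range from 50 nM to 3000 nM, an expectation that rests on compound 1 at 30 nM and on nothing more.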

Compound 4, concentration for 50% growth inhibition: 60 nM
Compound 4: the middle estimate sits 5.0-fold (0.70 log units) above what was measured; the measured number falls inside the stated range.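

In this assay, hydrogen in place of methoxy on an aromatic carbon gives a 2.0-fold higher number from compound 1 to compound 4 (0.30 log units; within the scatter), a step that lies within the usual scatter. For the compounds shown here, this is the first single-place step measured in the set, and it shows that at this carbon, meta to two methoxy groups and para to a large group, compound 1 at 30 nM and compound 4 at 60 nM cannot be told apart, so this methoxy is not required for growth inhibition at this level in this assay. Nothing measured here accounts for this outcome.

From the compounds shown here alone, whether a chlorine atom, an ethoxy group or a hydroxyl group at the same carbon would also stay within the scatter remains open, as does the effect of removing either of the two methoxy groups that remain in compound 4. Compound 2 stands at a limit of the assay, < 10 nM, so it gives no number against which the same change could be read on that compound.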